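Replacing Phenyl by Pyridin-3-yl in a Series of Modulators

The source may hold more compounds than are shown below. What is called first, only, known or untested is meant among the compounds shown, and "the series" means these compounds.

Compound 3 `O=C1C(=O)N(Cc2ccc(-c3ccccc3)cc2)c2ccc(OC(F)(F)F)cc21` shares its core with compound 1 `O=C1C(=O)N(Cc2ccc(-c3cncnc3)cc2)c2ccc(OC(F)(F)F)cc21` and compound 2 `O=C1C(=O)N(Cc2ccc(-c3ccncc3)cn2)c2ccc(OC(F)(F)F)cc21`. In a functional assay on CHO cells for positive allosteric modulation of muscarinic acetylcholine receptor M5 (Homo sapiens), read by FLIPR and calcium flux, with a stated time of 1 h (on this read-out lower numbers stand for smaller maximal responses and higher numbers for larger maximal responses), compound 1 gives 53%. For compound 2 in this assay no result is reported, so its value is "not determined" (no result reported). Compound 3 in this assay is reported only as a limit, < 60%, and not as a number. For the measured compounds named here, the step from compound 1 to compound 3 is therefore a step that the limit leaves unreadable from compound 1 to compound 3 and gives no readable size; the only evidence on it is the limit of < 60% in this assay, at which 1 of the 3 values shown sits.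

Compound 4 `O=C1C(=O)N(Cc2ccc(-c3cccnc3)cc2)c2ccc(OC(F)(F)F)cc21` differs from compound 3 by pyridin-3-yl in place of phenyl on an aromatic carbon, set para to a large group. Going by the values given here, no measured step matches this change directly. Compound 1 carries pyrimidin-5-yl at the same place and gives 53%. Compound 3 is reported only as a limit, < 60%. On this basis a single ring nitrogen in compound 4 is expected to leave the maximal response near that of compound 1. The expected step is a step that the limit leaves unreadable from compound 3 to compound 4, within the usual scatter. For compound 4 in this assay the estimate is 55%, between 40% and 70%.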

Compound 4, largest response reached (Emax), in percent of the reference or control that the assay uses: 51%
Compound 4: middle estimate off by 4 percentage points, on the high side; the range from low to high includes it.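

For the compounds shown here, compound 4 gives a second single number at this place, on an aromatic carbon para to a large group, so two rings that carry hetero atoms can now be compared directly in this assay, which the earlier compounds did not allow. Pyridin-3-yl in place of pyrimidin-5-yl gives a number 2 percentage points lower from compound 1 to compound 4 (within the scatter), so on this read-out the two rings cannot be told apart in this one pair. The step from compound 3 to compound 4 and the step from compound 1 to compound 3 cannot be read, because compound 3 is reported only as a limit: the limit of < 60% in this assay, at which 1 of the 4 values shown sits.

Going by these compounds, whether the phenyl ring of compound 3 gives a maximal response level with those of the two rings that carry hetero atoms therefore stays open, since the shared core has no single number with a ring of carbon only at this place. Also open, on these data alone, is how the maximal response would answer to a group of another kind here, such as an amine, a carboxylic acid or a longer chain in place of the aromatic ring.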